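The source may hold more compounds than are shown below. What is called first, only, known or untested is meant among the compounds shown, and "the series" means these compounds.

Compound 1 `O=C(CN(c1nc(Cl)nc2[nH]cnc12)C1CC1)N[C@@H](CC(=O)OCc1ccccc1)C(=O)OCc1ccccc1` is the weakest of the three measured compounds in a functional assay on the whole organism (Tail, strain ICR) with Mus musculus as the target, in the tail flick test, with a stated time of 60 min, at a dose of 25 umol/kg by the oral route (a higher number here means a stronger effect of the compound at the dose given, a lower number a weaker effect), where compound 1 gives 22.4%. Compound 3 `CC(C)(C)OC(=O)NCCCC[C@H](NC(=O)CN(c1ncnc2c1ncn2C1CCCCO1)C1CC1)C(=O)OCc1ccccc1` gives 32.7% in this assay, and compound 2 `O=C(O)CC[C@H](NC(=O)CN(c1nc(Cl)nc2[nH]cnc12)C1CC1)C(=O)O` gives 33.3%; both numbers stand above that of compound 1 by more than the usual scatter. Compound 4 `C[C@@H](O)[C@H](NC(=O)CN(c1nc(Cl)nc2[nH]cnc12)C1CC1)C(=O)OCc1ccccc1` has not been measured. It differs from compound 1 in one place: 1-hydroxyethyl in place of (benzyloxycarbonyl)methyl on a saturated chain carbon bound to an amide-type nitrogen and a carbonyl carbon. Within the data shown here, no measured pair shows this change, so its effect can only be guessed. The step from compound 1 to compound 4 is expected to be small and upward, estimated at a number 7.6 percentage points higher from compound 1 to compound 4 (within the scatter), though a step within the scatter would not surprise. Compound 4 is therefore expected to give about 30% in this assay, within a range from 12% to 48%.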

Compound 4, a percentage reported as activity, at one dose (the size of the read-out at that dose, not a potency): 29.7%
Compound 4: middle estimate off by 0.3 percentage points, on the high side; measured number inside the range.
By their numbers in this assay, from the lowest: compounds 1, 4, 3 and 2 (each within the scatter of the next, the first and the last beyond it).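

Putting 1-hydroxyethyl in place of (benzyloxycarbonyl)methyl on a saturated chain carbon bound to an amide-type nitrogen and a carbonyl carbon gives a number 7.3 percentage points higher from compound 1 to compound 4 (within the scatter) in this assay. At this place, then, a group of 3 heavy atoms with no ring can replace one of 11 heavy atoms with a six-membered aromatic ring, with no change beyond the scatter. Nothing available explains this step. On these data alone, whether an amine or a longer alkyl chain at this place would also leave the read-out within the scatter remains open.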